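The source may hold more compounds than are shown below. What is called first, only, known or untested is meant among the compounds shown, and "the series" means these compounds.

Compound 2 `CCOC(=O)c1cnc(-c2ccncc2)nc1NN1C(=O)C=C(C)C1=O` is one of three compounds that share a core and differ only in the group on an aromatic carbon of the six-membered ring with 2 nitrogen. In a functional assay on Jurkat cells for inhibition of nuclear factor NF-kappa-B complex (Homo sapiens) (a higher number here means a weaker inhibitor, a lower number a stronger inhibitor), compound 2 gives 6000 nM, the highest number of the three. Its nearest neighbour is compound 1 `CCOC(=O)c1cnc(C(C)(C)C)nc1NN1C(=O)C=C(C)C1=O`, which in this assay gives 1000 nM; the furthest is compound 3 `CCOC(=O)c1cnc(-c2ccc(Cl)s2)nc1NN1C(=O)C=C(C)C1=O`, which gives 300 nM. The measured steps are a 6.0-fold higher number from compound 1 to compound 2 (0.78 log units; beyond the scatter), a 3.3-fold lower number from compound 1 to compound 3 (0.52 log units; beyond the scatter) and a 20-fold lower number from compound 2 to compound 3 (1.30 log units; beyond the scatter).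

Compound 4 `CCOC(=O)c1cnc(Oc2ccccc2)nc1NN1C(=O)C=C(C)C1=O` has not yet been measured. Compared with compound 2 the change is phenoxy in place of pyridin-4-yl on an aromatic carbon. The step that bears most directly on it is the one that also removed pyridin-4-yl, a 20-fold lower number from compound 2 to compound 3 (1.30 log units; beyond the scatter), where a ring of carbon only took its place and the number fell strongly. Phenoxy likewise brings a ring of carbon only, so a lower number is expected for compound 4, though the single comparison leaves the size uncertain. The expected step is a 4.0-fold lower number from compound 2 to compound 4 (0.60 log units; beyond the scatter); compound 4 is estimated at 1500 nM, between 400 nM and 5000 nM.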

Compound 4, half-maximal inhibitory concentration: 15000 nM
Compound 4: the middle estimate sits 10-fold (1.00 log units) below what was measured; measured number outside the range, above it.
By their numbers in this assay, from the lowest: compound 3; then compound 1; then compound 2; then compound 4.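

Phenoxy gives the highest number of the four in this assay, with steps to it from all three other compounds (a 2.5-fold higher number from compound 2 to compound 4 (0.40 log units; beyond the scatter); a 15-fold higher number from compound 1 to compound 4 (1.18 log units; beyond the scatter); a 50-fold higher number from compound 3 to compound 4 (1.70 log units; beyond the scatter)). Removing pyridin-4-yl from this aromatic carbon, between two ring nitrogen atoms, therefore does not lower the number in itself: the result depends on which group enters, and a six-membered aromatic ring of carbon only, joined through oxygen, does worse here than the tert-butyl, pyridin-4-yl and 5-chlorothiophen-2-yl groups. Nothing available explains this rise with phenoxy.

The compounds shown leave open whether the oxygen link or the ring itself accounts for the result, which a phenyl group joined directly to the ring, or an anilino group, would help separate. They also leave open how much the chlorine of the best compound contributes, which plain thiophen-2-yl would address.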